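From isopropyl to cyclobutyl on an amine nitrogen

This account rests on a few compounds, and the source may have more. Where it says the series, first, only, none or still open, it means among the compounds named here.

Measured in a functional assay on aorta (Rattus norvegicus) for inhibition; a lower number here means that less compound is needed, a higher number that more compound is needed for the effect:
- compound 1 `CCCNC1=NS(=O)(=O)c2cc(Cl)ccc2N1`: 55500 nM
- compound 2 `CC(C)NC1=NS(=O)(=O)c2cc(Cl)ccc2N1`: 36300 nM

Not yet measured:
- compound 3 `O=S1(=O)N=C(NC2CCC2)Nc2ccc(Cl)cc21`

Compound 2 stands level with compound 1 within the usual scatter. The next change is cyclobutyl in place of isopropyl on an amine nitrogen. Going by the values given here, only one measured step bears on it, a 1.5-fold lower number from compound 1 to compound 2 (0.18 log units; within the scatter), with isopropyl in place of propyl on the same amine nitrogen. That is thin evidence, and neither measured compound has a ring there. The step expected is a 1.2-fold lower number from compound 2 to compound 3 (0.08 log units; within the scatter), which means nothing beyond the scatter in this assay, in either direction. Compound 3 is estimated at 30000 nM, with an expected range of 10000 nM to 80000 nM.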

Compound 3, half-maximal effective concentration: 34900 nM
The estimate for compound 3 lay 1.2-fold (0.07 log units) below the measured number, and the stated range covers the measured number.
By their numbers in this assay, from the lowest: compounds 3, 2 and 1 (each within the scatter of the next).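

In this assay, swapping isopropyl for a cyclobutyl ring on this amine nitrogen leaves the number level (a 1.0-fold lower number from compound 2 to compound 3 (0.02 log units; within the scatter)). The ring also stands level with the open propyl chain (a 1.6-fold lower number from compound 1 to compound 3 (0.20 log units; within the scatter)), so a straight chain, a branched chain and a small ring cannot be told apart at this position. No measurement available here explains this.

As far as these compounds go, whether a larger ring such as cyclohexyl, an aromatic group such as benzyl, or a chain ending in a carboxylic acid would also stand level remains open.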